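Swapping methyl for chloro on the amide-side ring

The compounds below may be only part of what the source reports. "The series", "measured", "known", "first", "only" and "open" are said of these compounds alone.

In an ADME assay on MT4 cells (Homo sapiens) for cytotoxicity, read by MTT assay (a higher number here means that more compound is tolerated, a lower number that less compound is tolerated), compound 1 `Cc1ccccc1NC(=O)CSc1nccn1-c1ccc(Cl)cc1` gives 160000 nM, the highest number among the three measured compounds. Compound 3 `Cc1ccccc1NC(=O)CSc1nccn1-c1cccc2ccccc12` gives 34600 nM and compound 2 `O=C(CSc1nccn1-c1cccc2ccccc12)Nc1ccccc1Br` gives 30500 nM, both well below compound 1. Compound 4 `O=C(CSc1nccn1-c1ccc(Cl)cc1)Nc1ccccc1Cl` has not yet been measured; it is built from compound 1 by the change (chloro in place of methyl on an aromatic carbon). Within the data shown here, the one measured step at the same place is a 1.1-fold higher number from compound 2 to compound 3 (0.05 log units; within the scatter), which shows that methyl and bromo are interchangeable there. Among the measured compounds shown here, since chloro is the only new group and the measured exchange at this position left this assay unmoved, the step is expected to be a 1.1-fold lower number from compound 1 to compound 4 (0.06 log units; within the scatter). Compound 4 is therefore estimated at 140000 nM, within the range 60000 nM to 320000 nM.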

Compound 4, half-maximal cytotoxic concentration: > 330000 nM
Compound 4: only a limit was reported; the forecaster's own chance of this, stated with the estimate: 10%; middle value at least 2.3-fold (0.37 log units) from the limit.
By their numbers in this assay, from the lowest: compounds 2 and 3 (each within the scatter of the next); then compound 1. At a limit, above all of these: compound 4.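

Exchanging methyl for chloro at this position gives an at least 2.0-fold higher number from compound 1 to compound 4 (0.31 log units; beyond the scatter), whereas the earlier exchange on the other core gave a 1.1-fold higher number from compound 2 to compound 3 (0.05 log units; within the scatter). The group here can therefore matter in this assay, at least on the core of compound 1. The number for compound 4 is only a limit of the assay: the limit of > 330000 nM in this assay, at which 1 of the 4 values shown sits.

From the compounds shown here alone, the true size of this step stays open. So does the question of whether bromo, an amine or a carboxylic acid at this same place on the core of compound 1 would follow chloro or methyl.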